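The compounds below may be only part of what the source reports. "The series", "measured", "known", "first", "only" and "open" are said of these compounds alone.

Measured in a functional assay on Ehrlich cells (Mus musculus) for cytotoxicity, read by trypan blue exclusion, with a stated time of 48 h; on this read-out higher numbers stand for weaker inhibition and lower numbers for stronger inhibition:
compound 1 `Cc1ccc(-c2csc(NC(=O)COc3ccccc3C)n2)cc1`: 54900 nM
compound 2 `Cc1ccc(-c2csc(NC(=O)COc3ccccc3C(C)C)n2)cc1`: 42800 nM
compound 3 `Cc1ccc(-c2csc(NC(=O)COc3ccc(F)cc3)n2)cc1`: 18100 nM

Among these three numbers compound 1 gives the highest. The nearest is a 1.3-fold lower number from compound 1 to compound 2 (0.11 log units; within the scatter), which stays within the scatter; the furthest is a 3.0-fold lower number from compound 1 to compound 3 (0.48 log units; beyond the scatter), which goes beyond it. Compound 4 `Cc1ccccc1OCC(=O)Nc1nc(-c2ccc(Cl)cc2)cs1` differs from compound 1 by chloro in place of methyl on an aromatic carbon. Neither measured step bears on this position: the step from compound 1 to compound 2 and the step from compound 1 to compound 3 both alter the other aromatic ring. Among the measured compounds shown here, with no comparable step to lean on, the number expected for compound 4 means a 1.2-fold lower number from compound 1 to compound 4 (0.09 log units; within the scatter), not beyond the scatter. In this assay compound 4 is therefore estimated at 45000 nM, between 15000 nM and 130000 nM.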

Compound 4, half-maximal inhibitory concentration: 63100 nM
Estimate against measurement, compound 4: 1.4-fold (0.15 log units) below; low and high end bracket the measured number.
By their numbers in this assay, from the lowest: compound 3; then compounds 2, 1 and 4 (each within the scatter of the next).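

Among the compounds shown here, compound 4 is the first to change the 4-methylphenyl group, and in this assay the swap to 4-chlorophenyl gives a 1.1-fold higher number from compound 1 to compound 4 (0.06 log units; within the scatter) and so no readable shift. At this place, para to a large group, chloro and methyl cannot be told apart on this read-out, whereas the change to the other aromatic ring in compound 3 went beyond the scatter. Nothing measured here accounts for this result. As far as these compounds go, whether an amine, a methoxy or a carboxylic acid at this place would move the number remains open, as does whether 4-chlorophenyl would pair with the 4-fluorophenyl of compound 3.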